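Methyl on the acetoxy chain: carrying the step across cores

The source may hold more compounds than are shown below. What is called first, only, known or untested is meant among the compounds shown, and "the series" means these compounds.

Compound 1 `COc1ccc(C(=O)/C(=C/C2CCCCC2)CCOC(C)=O)cc1` and compound 3 `COc1ccc(C(=O)/C(=C/C2CCCCC2)CC(C)OC(C)=O)cc1` share one core and differ only by methyl in place of hydrogen on a saturated chain carbon bound to an oxygen next to a carbonyl group and a saturated chain carbon. In a functional assay on NB-4 cells (Homo sapiens) for inhibition, read by XTT assay, with a stated time of 48 h (a lower number here means a stronger inhibitor, a higher number a weaker inhibitor), compound 1 reports only a limit, > 100000 nM. In this assay compound 3 gives 33400 nM. The step of an at least 2.9-fold lower number from compound 1 to compound 3 (0.47 log units; beyond the scatter) rests on the limit of > 100000 nM in this assay, at which 1 of the 3 values shown sits, and is therefore a bound on its true size rather than a number. Compound 2 `COc1ccc(C(=O)/C(=C/c2c(F)c(F)c(F)c(F)c2F)CCOC(C)=O)cc1` carries a different core; the difference between the two cores is not broken down here. In this assay compound 2 gives 28500 nM, which lies within the scatter of compound 3. Compound 4 `COc1ccc(C(=O)/C(=C/c2c(F)c(F)c(F)c(F)c2F)CC(C)OC(C)=O)cc1` applies the same change to compound 2, (methyl in place of hydrogen on a saturated chain carbon bound to an oxygen next to a carbonyl group and a saturated chain carbon), at the same place. On the single measured occurrence, the step from compound 2 to compound 4 is expected to be a 2.4-fold lower number from compound 2 to compound 4 (0.38 log units; beyond the scatter), comparable to the measured one. Compound 4 is accordingly estimated at 12000 nM, with a range from 5000 nM to 30000 nM.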

Compound 4, half-maximal inhibitory concentration: 49000 nM
Estimate against measurement, compound 4: 4.1-fold (0.61 log units) below, outside the stated range (above it).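

On the core of compound 2 the methyl change gives a 1.7-fold higher number from compound 2 to compound 4 (0.24 log units; within the scatter) in this assay, so the lower number seen on the core of compound 1 does not carry over: the same change on two cores in this assay, an at least 2.9-fold lower number (0.47 log units; beyond the scatter) from compound 1 to compound 3 and a 1.7-fold higher number (0.24 log units; within the scatter) from compound 2 to compound 4, at least 5.1-fold (0.71 log units) apart, beyond the scatter of two such steps. The step on the core of compound 1 rests on a limit, so the gap between the two steps is a bound and not a number: the limit of > 100000 nM in this assay, at which 1 of the 4 values shown sits. With one pair on each core, this shows that the step differs between these two cores; it does not show which feature of the cores goes with the difference, or how the change would read on any other core.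

The compounds shown leave open whether an ethyl group in place of the methyl would also differ between the two cores. They also leave open how a free hydroxyl in place of the acetoxy group would read on either core.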